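The compounds below may be only part of what the source reports. "The series", "measured", "known", "first", "only" and "open" are said of these compounds alone.

Compound 1 `O=C1N=C(N2CCNCC2)CN1c1ccc(Cl)cc1` and compound 2 `O=C1N=C(N2CCCC2)CN1c1ccc(Cl)cc1` share one core; in a physicochemical assay for lipophilicity (on this read-out lower numbers stand for lower lipophilicity and higher numbers for higher lipophilicity), compound 1 gives 2.3 and compound 2 gives 2. The change between them, (pyrrolidin-1-yl in place of piperazin-1-yl on a carbon with a double bond to nitrogen), made a step of a number 0.30 log units lower from compound 1 to compound 2 (within the scatter). Compound 3 `O=C1C=C(N2CCNCC2)C(=O)N1c1ccc(Cl)cc1` has a different core; how the two cores differ is not broken down here. In this assay compound 3 gives 3.4. Compound 4 `O=C1C=C(N2CCCC2)C(=O)N1c1ccc(Cl)cc1` is not yet measured. It differs from compound 3 by pyrrolidin-1-yl in place of piperazin-1-yl on a double-bonded ring carbon, the same kind of change as that from compound 1 to compound 2, though the place differs: there the carbon has a double bond to nitrogen and lies next to the ring nitrogen, here it is a double-bonded ring carbon of a ring with one nitrogen. A step of similar size is expected, a number 0.30 log units lower from compound 3 to compound 4 (within the scatter), resting on the step of a number 0.30 log units lower from compound 1 to compound 2 (within the scatter). For compound 4 in this assay the estimate is 3.1, between 2.7 and 3.5.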

Compound 4, partition coefficient: 3
Compound 4: the middle estimate sits 0.10 log units above what was measured; low and high end bracket the measured number.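

In this assay the swap to pyrrolidin-1-yl from piperazin-1-yl on the core of compound 3 gave a modest step beyond the scatter (a number 0.40 log units lower from compound 3 to compound 4 (beyond the scatter)), while the same kind of swap on the core of compound 1 stayed within it (a number 0.30 log units lower from compound 1 to compound 2 (within the scatter)). The change can therefore be made on both cores, but its step can be read beyond the scatter on only one of them, and two pairs set no rule for any other core. Nothing here explains the size of either step.

Still open, going by these compounds, is how another amine, such as morpholin-4-yl or dimethylamino, would read on either core at the same place. On these data alone, a group carrying a carboxylic acid, or a longer chain on the piperazine nitrogen, is equally open.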